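Moving One Chlorine on a Dichlorophenyl Group

This account rests on a few compounds, and the source may have more. Where it says the series, first, only, none or still open, it means among the compounds named here.

Compound 1 `COc1cc(/C=C2\CN(C)C/C(=C\c3ccc(Cl)cc3)C2=O)cc(OC)c1`: 5860 nM
Compound 2 `COc1cc(/C=C2\CN(C)C/C(=C\c3ccc(Br)cc3)C2=O)cc(OC)c1`: 4270 nM
Compound 3 `COc1cc(/C=C2\CN(C)C/C(=C\c3ccc(Cl)cc3Cl)C2=O)cc(OC)c1`: 6070 nM

In a functional assay on THP-1 cells (Homo sapiens) for cytotoxicity, read by MTT assay, with a stated time of 24 h (on this read-out lower numbers stand for stronger inhibition and higher numbers for weaker inhibition), compound 3 (6070 nM) cannot be told apart from the other two compounds. Its gaps to them are a 1.0-fold higher number from compound 1 to compound 3 (0.02 log units; within the scatter) and a 1.4-fold higher number from compound 2 to compound 3 (0.15 log units; within the scatter), and both lie within the scatter.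

The next compound is compound 4 `COc1cc(/C=C2\CN(C)C/C(=C\c3ccc(Cl)c(Cl)c3)C2=O)cc(OC)c1`, which has 3,4-dichlorophenyl in place of 2,4-dichlorophenyl on a double-bonded chain carbon bound to a double-bonded ring carbon. Among the compounds with values here, no measured pair tests this exact swap, so the evidence is indirect. Adding a chloro gave a 1.0-fold higher number from compound 1 to compound 3 (0.02 log units; within the scatter), and exchanging chloro for bromo gave a 1.4-fold lower number from compound 1 to compound 2 (0.14 log units; within the scatter). Both changes to this same aromatic ring left the number within the scatter, so no step beyond the scatter is expected in this assay, and no direction can be favoured with confidence.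

The expected step is a 1.1-fold lower number from compound 3 to compound 4 (0.06 log units; within the scatter).

The estimated value for compound 4 is 5300 nM, with an expected range from 2900 nM to 9500 nM.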

Compound 4, half-maximal inhibitory concentration: 3260 nM
Compound 4: the middle estimate sits 1.6-fold (0.21 log units) above what was measured, and the stated range covers the measured number.
By their numbers in this assay, from the lowest: compounds 4, 2, 1 and 3 (each within the scatter of the next).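

In this assay, 3,4-dichlorophenyl in place of 2,4-dichlorophenyl keeps the same atoms and only rearranges them, and this gives a 1.9-fold lower number from compound 3 to compound 4 (0.27 log units; within the scatter) on the same scale as the earlier changes. The two other new comparisons agree: a chloro in place of hydrogen on an aromatic carbon gives a 1.8-fold lower number from compound 1 to compound 4 (0.25 log units; within the scatter), and 3,4-dichlorophenyl in place of 4-bromophenyl gives a 1.3-fold lower number from compound 2 to compound 4 (0.12 log units; within the scatter), both within the scatter. Thus, on the double-bonded chain carbon, the placement of a chlorine now joins the number of chlorines and the choice of chlorine or bromine as changes with no step beyond the scatter.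

No supporting measurement explains these small steps. On these data alone, whether this position would remain as unresponsive with a non-halogen group on the ring, such as an amine or a carboxylic acid, stays open.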